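Chloro to Trifluoromethyl on a Growth-Inhibition Series

This account rests on a few compounds, and the source may have more. Where it says the series, first, only, none or still open, it means among the compounds named here.

Measured compounds:
- Compound 1 `O=C(Nc1cccc(-n2cc(-c3ccncc3)c(-c3ccc(Cl)c(O)c3)n2)c1)Nc1ccc(Cl)c(Cl)c1`: > 32500 nM
- Compound 2 `COc1cc(-c2nn(-c3cccc(NC(=O)c4cccc(C(F)(F)F)c4)c3)cc2-c2ccncc2)ccc1Cl`: > 50000 nM
- Compound 3 `COc1cc(-c2nn(-c3cccc(NC(=O)c4ccccc4)c3)cc2-c2ccncc2)ccc1Cl`: > 100000 nM

All three values in a functional assay on PC-3 cells (Homo sapiens) for inhibition, read by sulforhodamine B assay, with a stated time of 48 h (on this read-out lower numbers stand for stronger inhibition of growth and higher numbers for weaker inhibition of growth), are limits of the assay rather than numbers. Compound 1 stands at a limit, (the limit of > 32500 nM in this assay, at which 1 of the 3 values shown sits). Compound 2 sits at another limit, (the limit of > 50000 nM in this assay, at which 1 of the 3 values shown sits). Compound 3 sits at the third, (the limit of > 100000 nM in this assay, at which 1 of the 3 values shown sits). Among the compounds with values here, the one pair that differs in a single place, compound 2 and compound 3, gives a step that the two limits leave unreadable from compound 2 to compound 3, so nothing can be read from it about the size of any step, and none of the measured pairs touches the change now considered.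

Compound 4 `O=C(Nc1cccc(-n2cc(-c3ccncc3)c(-c3ccc(Cl)c(O)c3)n2)c1)Nc1ccc(Cl)c(C(F)(F)F)c1` differs from compound 1 by trifluoromethyl in place of chloro on an aromatic carbon. Within the data shown here, no measured step bears on this change, and the starting point is itself only a limit. The account therefore expects compound 4 to remain at or near the limit in this assay, with no step beyond the scatter that can be foreseen; the expected step is a step that the limit leaves unreadable from compound 1 to compound 4. For compound 4 the estimate in this assay is 40000 nM, within a range from 12000 nM to 130000 nM, because compound 1 gives > 32500 nM and offers no number to move from.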

Compound 4, concentration for total growth inhibition: 2200 nM
Beside the measured number, compound 4's estimate is 18-fold (1.26 log units) above it; the whole stated range lies above it.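

In this assay, putting trifluoromethyl in place of chloro on an aromatic carbon, ortho to a chloro group and meta to a large group, gives an at least 14-fold lower number from compound 1 to compound 4 (1.16 log units; beyond the scatter), so this position of the 3,4-dichlorophenyl ring responds to a single change of group. Within the data shown here, the earlier compounds could not show this: all of them stand at limits of the assay, the one step among them cannot be read, and compound 4 is the first to give a number, which turns the 4-chloro-3-(trifluoromethyl)phenyl compound into a usable reference point. None of the measurements shown accounts for why this change has so large an effect.

Among these compounds, compound 1 and compound 4 are the only pair carrying this change, so it remains open whether the step would recur on a different core, and compound 2, which also carries trifluoromethyl, differs from compound 4 in more than one place and cannot settle that. On these data alone, it also remains open whether the response is particular to trifluoromethyl or would extend to another group at this position, such as a nitrile or a bromine.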